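From phenylcarbamoyl to methyl(phenyl)amino on a shared core

This account rests on a few compounds, and the source may have more. Where it says the series, first, only, none or still open, it means among the compounds named here.

Going by the values given here, two related compounds, compound 1 (`O=C(Nc1ccccc1)c1cnc(NCc2c(F)ccc3c2CCO3)n2cnnc12`) and compound 2 (`CC(=O)N1CCC(c2cnc(NCc3c(F)ccc4c3CCO4)c3cn[nH]c(=O)c23)CC1`), have so far been measured in a physicochemical assay for lipophilicity, using the shake flask method, in phosphate buffer, measured as octanol-water partition, with a stated time of 30 min, at pH 7.4 (a higher number here means a more lipophilic compound, a lower number a more polar compound), and give the only numbers available. Compound 1 stands higher of the two at 4.1 and compound 2 lies lower at 2.9 with a gap beyond the scatter. These two compounds differ in more than one place, so their gap does not show what a single change would do.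

Compound 3 (`CN(c1ccccc1)c1cnc(NCc2c(F)ccc3c2CCO3)n2cnnc12`) has not yet been measured. It departs from compound 1 in one place, with methyl(phenyl)amino in place of phenylcarbamoyl on an aromatic carbon. Both the group that leaves and the group that enters hold a six-membered aromatic ring of carbon only, and the rest of the structure stays as it is.

Among the compounds with values here, no measured step of this kind exists, so the expectation starts from compound 1 at 4.1 and allows only a small upward move that stays within the scatter. The expected step is a number 0.20 log units higher from compound 1 to compound 3 (within the scatter) and carries a wide margin. In this assay compound 3 is estimated at 4.3 (expected range 3.7 to 4.9).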

Compound 3, distribution coefficient: 3.6
Beside the measured number, compound 3's estimate is 0.70 log units above it; measured number below the stated range.
By their numbers in this assay, from the lowest: compound 2; then compound 3; then compound 1.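

At this place on the shared core, on an aromatic carbon two atoms from the ring nitrogen, this assay now gives its first readable single change, a number 0.50 log units lower from compound 1 to compound 3 (beyond the scatter) when methyl(phenyl)amino stands in place of phenylcarbamoyl. The six-membered aromatic ring of carbon only is present on both sides of this step, so the number at this position responds to the link that carries the ring and not just to the presence of the ring; the change removes the double bond outside aromatic rings and the hydrogen-bond donor, and it goes from 9 heavy atoms to 8. Nothing measured separates these differences or explains the step.

This remains a single step at a single position, so it cannot show whether a similar move would appear on another core or with another group on the ring. The compounds shown also leave open where the same position would fall with a phenoxy group, a benzyl group or an amino group without its methyl, any of which would help to separate the contribution of the link from that of the methyl.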